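Chain Extension at the Pendant Aryl Group of a Pyrazole Series

The compounds below may be only part of what the source reports. "The series", "measured", "known", "first", "only" and "open" are said of these compounds alone.

Compound 1: `CN(Cc1ccccc1)C(=O)c1cc2c(Cc3ccccc3)n[nH]c2cc1O` — 980 nM
Compound 2: `Cc1cccc(Cc2n[nH]c3cc(O)c(C(=O)N(C)Cc4ccccc4)cc23)c1` — 490 nM
Compound 3: `CN(Cc1ccccc1)C(=O)c1cc2c(Cc3ccc(Cl)cc3)n[nH]c2cc1O` — "not determined" (no result reported)

Three compounds sharing one core were examined in a functional assay on A2780 cells (Homo sapiens) for antiproliferative activity, read by resazurin assay, with a stated time of 72 h; on this read-out higher numbers stand for weaker inhibition and lower numbers for stronger inhibition. Within the data shown here, compound 1 gives 980 nM, and compound 2 gives 490 nM; the one measured step, a 2.0-fold lower number from compound 1 to compound 2 (0.30 log units; within the scatter), lies within the scatter, so the two values tell nothing of order. Compound 3 gives "not determined" (no result reported), so its place among the others cannot be given.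

The step to compound 4, `CN(Cc1ccccc1)C(=O)c1cc2c(CCc3ccccc3)n[nH]c2cc1O`, is benzyl in place of 4-chlorophenyl on a saturated chain carbon bound to an aromatic carbon. Among the measured compounds shown here, no measured step bears directly on it: the only step in hand, a 2.0-fold lower number from compound 1 to compound 2 (0.30 log units; within the scatter), concerns a methyl on an aromatic carbon and says nothing about lengthening the chain between the core and the pendant ring or about removing the chlorine. Compound 4 is, however, the nearest relative of compound 1, differing from it only by one extra chain carbon, and compound 1 gives 980 nM. For the measured compounds named here, with no step to guide the direction, the expectation for compound 4 is a value near that of compound 1, with no change beyond the scatter foreseen in either direction, but with wide uncertainty.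

Compound 4 is therefore estimated at 1500 nM, with a range from 300 nM to 7000 nM.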

Compound 4, half-maximal inhibitory concentration: 4600 nM
Beside the measured number, compound 4's estimate is 3.1-fold (0.49 log units) below it; the range from low to high includes it.
By their numbers in this assay, from the lowest: compounds 2 and 1 (each within the scatter of the next); then compound 4.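

In this assay, among these compounds, lengthening the chain that carries the pendant ring is the first change in this set to move the number beyond the scatter: the step shows a 4.7-fold higher number from compound 1 to compound 4 (0.67 log units; beyond the scatter), so phenethyl on the shared core goes with weaker inhibition than the shorter benzyl group of compound 1. The step shows a 9.4-fold higher number from compound 2 to compound 4 (0.97 log units; beyond the scatter), but this larger gap combines the added chain carbon with the loss of the methyl of the 3-methylphenyl group, so it cannot be credited to chain length alone. Nothing given here explains why the longer chain gives the higher number.

Going by these compounds, compound 3 has no reported result, so the steps linking it to compound 4 cannot be read, and what the chlorine of its 4-chlorobenzyl group does in this assay remains unknown. Among the compounds shown here, with compound 4 as the only example of the longer chain, it also remains open whether a still longer chain, an ether oxygen within the chain, or an amine on the pendant ring would raise the number further or bring it back down.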